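Removing the bromo from the core of compound 2

This account rests on a few compounds, and the source may have more. Where it says the series, first, only, none or still open, it means among the compounds named here.

The study compares three measured compounds sharing a core. Compound 1 `COc1ccc(S(=O)(=O)N2CCc3cccc(NC(=O)c4ccc(C#N)cc4)c32)cc1`, compound 2 `COc1ccc(S(=O)(=O)N2CCc3cc(Br)cc(NC(=O)c4ccco4)c32)cc1` and compound 3 `COc1ccc(S(=O)(=O)N2CCc3cccc(NS(=O)(=O)c4ccc([N+](=O)[O-])cc4)c32)cc1` were all tested in a functional assay on KB cells (Homo sapiens) for cytotoxicity; on this read-out higher numbers stand for weaker inhibition and lower numbers for stronger inhibition. In this assay compound 1 gives 105 nM, compound 2 gives 89 nM and compound 3 gives 1100 nM. Compound 2 has the lowest number of the three; the gap to compound 1 lies within the scatter, while the gap to compound 3 lies beyond it.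

The unmeasured compound 4 `COc1ccc(S(=O)(=O)N2CCc3cccc(NC(=O)c4ccco4)c32)cc1` differs from compound 2 in one place: hydrogen in place of bromo on an aromatic carbon. Among the compounds with values here, no measured pair shows this change alone, so its effect is unknown from the numbers. Compound 1 also carries hydrogen at that carbon and sits close to compound 2, which suggests only a modest shift. The step from compound 2 to compound 4 is expected to be small, leaning toward weaker inhibition, at a 2.0-fold higher number from compound 2 to compound 4 (0.31 log units; beyond the scatter). For compound 4 the estimate in this assay is 180 nM, with a range from 60 nM to 600 nM.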

Compound 4, half-maximal inhibitory concentration: 9.6 nM
The estimate for compound 4 lay 19-fold (1.27 log units) above the measured number; the whole stated range lies above it.
By their numbers in this assay, from the lowest: compound 4; then compounds 2 and 1 (each within the scatter of the next); then compound 3.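

Removing the bromo from this aromatic carbon gives a 9.3-fold lower number from compound 2 to compound 4 (0.97 log units; beyond the scatter) in this assay and so shows that the position, meta to a ((furan-2-yl)carbonyl)amino group, is sensitive to what it carries. With the furan-2-yl amide in place, hydrogen at this carbon gives the lower number. Within the data shown here, compound 4 also links the two amides on a bare core, since furan-2-yl in place of 4-cyanophenyl on the carbonyl carbon gives an 11-fold lower number from compound 1 to compound 4 (1.04 log units; beyond the scatter) and shows that each single change has a large effect, which the close values of the earlier compounds did not reveal. Nothing at hand explains either step. Open, from the compounds shown here alone, is how a fluoro, chloro, methyl or methoxy group would fare at this carbon, and whether bromo there would have the same effect alongside the 4-cyanophenyl amide.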